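Notes on one amide series: chloro to hydroxy

This account rests on a few compounds, and the source may have more. Where it says the series, first, only, none or still open, it means among the compounds named here.

Compound 1 `CCCCCCCCCCCCCCNC(=O)[C@H](CO)/N=C/c1ccccc1C` gives 87700 nM in a functional assay on cells (Homo sapiens) for cytotoxicity, read by MTT assay, with a stated time of 24 h; a higher number here means a weaker inhibitor, a lower number a stronger inhibitor. Compound 2 `CCCCCCCCCCCCCCNC(=O)[C@H](CO)/N=C/c1ccccc1Cl` gives 10300 nM in this assay, and compound 3 `CCCCCCCCCCCCCCNC(=O)[C@H](CO)NCc1ccccc1Cl` gives 43700 nM in this assay. Compound 3 thus stands second highest of the three numbers, nearest compound 1 and furthest from compound 2; the relevant steps are a 2.0-fold lower number from compound 1 to compound 3 (0.30 log units; within the scatter) and a 4.2-fold higher number from compound 2 to compound 3 (0.63 log units; beyond the scatter). Compound 4 `CCCCCCCCCCCCCCNC(=O)[C@H](CO)NCc1ccccc1O` differs from compound 3 by hydroxy in place of chloro on an aromatic carbon. Going by the values given here, the only measured step at that aromatic carbon is an 8.5-fold lower number from compound 1 to compound 2 (0.93 log units; beyond the scatter), which concerns a different pair of groups; no measured step swaps chloro for hydroxy, so the direction is uncertain. A step within or just beyond the scatter is expected, a 1.4-fold higher number from compound 3 to compound 4 (0.14 log units; within the scatter). Compound 4 is therefore estimated at 60000 nM, range 20000 nM to 180000 nM, in this assay.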

Compound 4, half-maximal inhibitory concentration: 75300 nM
Beside the measured number, compound 4's estimate is 1.3-fold (0.10 log units) below it; measured number inside the range.
By their numbers in this assay, from the lowest: compound 2; then compounds 3, 4 and 1 (each within the scatter of the next).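

In this assay, hydroxy in place of chloro on an aromatic carbon, ortho to a large group, gives no readable difference on this core: a 1.7-fold higher number from compound 3 to compound 4 (0.24 log units; within the scatter). The other steps place compound 4 with compound 1, a 1.2-fold lower number from compound 1 to compound 4 (0.07 log units; within the scatter), and apart from compound 2, a 7.3-fold higher number from compound 2 to compound 4 (0.86 log units; beyond the scatter). Among the compounds shown, only compound 2 stands beyond the scatter of all the others. No evidence at hand bears on this result.

As far as these compounds go, whether hydroxy in place of chloro would read the same way on the core of compound 2 stays open. So does whether a methoxy or an amine on this aromatic carbon would stand apart from chloro.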